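The source may hold more compounds than are shown below. What is called first, only, known or untested is meant among the compounds shown, and "the series" means these compounds.

Compound 1 `CC(=O)CC[C@]1(C(C)=O)C(=O)O[C@@H](OC(C)=O)[C@H]1C`: 8000 nM
Compound 2 `CC(=O)O[C@@H]1OC(=O)[C@@](C(C)=O)(C2SCCCS2)[C@@H]1C`: > 50000 nM

Both were tested in a functional assay on DA-3 cells for cytotoxicity against DA-3 cell line (Mus musculus), read by MTT assay; a lower number here means a stronger inhibitor, a higher number a weaker inhibitor. Compound 1 gives 8000 nM there. Compound 2 gives > 50000 nM in this assay, and this is a limit of the assay rather than a number. Compound 2 therefore sits at the limit of > 50000 nM in this assay, at which 1 of the 2 values shown sits, and the step of an at least 6.2-fold higher number from compound 1 to compound 2 (0.79 log units; beyond the scatter) is known only as a bound, not as a settled size. The unmeasured compound 3 `CC(=O)O[C@@H]1OC(=O)[C@@H](C(C)=O)[C@@H]1C` differs from compound 2 by a hydrogen atom in place of a group of 6 heavy atoms (4 carbon, 2 sulfur; one six-membered non-aromatic ring with 2 hetero atoms), on a saturated ring carbon. Among the measured compounds shown here, no measured step removes a group from this saturated ring carbon and leaves a hydrogen; the only step on that carbon, an at least 6.2-fold higher number from compound 1 to compound 2 (0.79 log units; beyond the scatter), traded a chain for the six-membered ring and made the compound weaker, which says nothing direct about the bare hydrogen. As far as these compounds go, with compound 2 at a limit, the direction of the change remains open. Compound 3 is expected at 30000 nM, within 8000 nM to 100000 nM. The estimated step is an at least 1.6-fold lower number from compound 2 to compound 3 (0.22 log units; that floor lies within the scatter).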

Compound 3, half-maximal inhibitory concentration: > 50000 nM
Compound 3 ended at the assay's limit (the forecaster's own chance of this, stated with the estimate: 40%); middle value at least 1.6-fold (0.22 log units) away from the limit.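

In this assay, hydrogen in place of 2-acetylethyl on this saturated ring carbon gives an at least 6.2-fold higher number from compound 1 to compound 3 (0.79 log units; beyond the scatter), so the bare ring carbon does not keep the activity of compound 1. Among the compounds shown here, the earlier step showed this loss only for the six-membered ring; now neither that ring nor hydrogen matches the 2-acetylethyl chain, the only group of the three that gives a value rather than a limit. The step between compound 2 and compound 3 cannot be read, and each of these two compounds stands at a limit of the assay: the limit of > 50000 nM in this assay, at which 2 of the 3 values shown sit.

As far as these compounds go, how far the activity of compound 2 and compound 3 lies beyond that limit stays open. Also open, from the compounds shown here alone, is whether the chain needs its length or its carbonyl, which an ethyl group, a longer chain, or a chain ending in a carboxylic acid or an amine could test.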